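Trading a methyl for 4-bromophenyl on a saturated ring carbon

The source may report more compounds than this note shows. Statements on the series, on what has been measured and on what is new or still open speak of the compounds shown alone.

Among the compounds with values here, only two compounds have numbers so far. In a functional assay on HL-60 cells (Homo sapiens) for cytotoxicity, read by CCK-8 assay, with a stated time of 24 h (on this read-out higher numbers stand for weaker inhibition and lower numbers for stronger inhibition), compound 1 `C=CC(=O)N1C(=O)CC(c2ccc(C)cc2)Sc2ccccc21` gives 94400 nM while compound 2 `C=CC(=O)N1C(=O)CC(C)Sc2ccccc21` gives 199000 nM and so holds the higher of the two numbers, which means the weaker inhibition of the pair. The change to compound 3 `C=CC(=O)N1C(=O)CC(c2ccc(Br)cc2)Sc2ccccc21` is 4-bromophenyl in place of methyl on a saturated ring carbon and it puts 4-bromophenyl in place of methyl on a saturated ring carbon next to the ring sulfur. Within the data shown here, one measured step bears on this change, a 2.1-fold higher number from compound 1 to compound 2 (0.32 log units; beyond the scatter) with methyl in place of 4-methylphenyl on that same carbon. Compound 3 runs the other way and brings a substituted phenyl ring back. Among the measured compounds shown here, a modest step toward a lower number is therefore expected in this assay as well, although no measured compound shows how 4-bromophenyl compares with 4-methylphenyl. The expected move is a 2.3-fold lower number from compound 2 to compound 3 (0.37 log units; beyond the scatter) and it remains only an estimate. For compound 3 the estimate is 85000 nM with an expected range of 35000 nM to 190000 nM until a measurement is available.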

Compound 3, half-maximal inhibitory concentration: 126000 nM
Estimate against measurement, compound 3: 1.5-fold (0.17 log units) below; the range from low to high includes it.
By their numbers in this assay, from the lowest: compounds 1, 3 and 2 (each within the scatter of the next, the first and the last beyond it).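

In this assay, 4-bromophenyl in place of methyl on this saturated ring carbon gives a 1.6-fold lower number from compound 2 to compound 3 (0.20 log units; within the scatter), so this swap cannot be separated from the ordinary variation between repeated measurements, although the earlier swap involving 4-methylphenyl could be. Changing only the substituent on the phenyl ring, with bromo in place of methyl on an aromatic carbon, gives a 1.3-fold higher number from compound 1 to compound 3 (0.13 log units; within the scatter), so the bromo and methyl compounds cannot be told apart in these data. No supporting measurement is available to explain where any of the three compounds falls.

From the compounds shown here alone, the three compounds therefore leave the effect of this position only loosely defined, and it remains open whether a longer chain in place of the methyl, or a phenyl ring bearing an amine or a carboxylic acid, would give a clearly different number. All three also carry the same vinylcarbonyl group on the ring nitrogen, so these compounds cannot show what would happen if a simple acetyl group stood there instead.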